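From diethylamino to dimethylamino on a shared core

The source may hold more compounds than are shown below. What is called first, only, known or untested is meant among the compounds shown, and "the series" means these compounds.

In a functional assay on A549 cells (Homo sapiens) for cytotoxicity, read by MTT assay, with a stated time of 72 h (a higher number here means a weaker inhibitor, a lower number a stronger inhibitor), compound 3 `CCN(CC)Cc1ccc2nc(NC(=O)N/N=C/c3cn(Cc4ccc(Cl)cc4)c4ccccc34)sc2c1` gives 2940 nM. Compound 1 `CN(C)Cc1ccc2nc(NC(=O)N/N=C/c3cn(Cc4ccccc4Cl)c4ccccc34)sc2c1` gives 1080 nM, a lower number by more than the scatter, while compound 2 `CN(C)Cc1ccc2nc(NC(=O)N/N=C/c3cn(Cc4ccc(C(C)(C)C)cc4)c4ccccc34)sc2c1` at 1850 nM lies within the scatter of compound 3.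

Compound 4 `CN(C)Cc1ccc2nc(NC(=O)N/N=C/c3cn(Cc4ccc(Cl)cc4)c4ccccc34)sc2c1` has not yet been measured. It differs from compound 3 in one place: dimethylamino in place of diethylamino on a saturated chain carbon bound to an aromatic carbon. That is, dimethylamino stands in place of diethylamino on a saturated chain carbon bound to an aromatic carbon.

Among the measured compounds shown here, no measured pair isolates this change. For the measured compounds named here, the only measured step, a 1.7-fold higher number from compound 1 to compound 2 (0.23 log units; within the scatter), puts 4-(tert-butyl)phenyl in place of 2-chlorophenyl elsewhere in the molecule, so it bears on the change only indirectly. It does suggest that compounds carrying dimethylamino can stay close together despite a different group at that other place. Compound 1 at 1080 nM and compound 2 at 1850 nM both carry dimethylamino, as compound 4 does, and they are the best available guide. A modest move towards a lower number is therefore expected, probably no larger than the scatter. The expected step is a 1.6-fold lower number from compound 3 to compound 4 (0.21 log units; within the scatter). For compound 4 the estimated value is 1800 nM, with an expected range from 850 nM to 3600 nM.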

Compound 4, half-maximal inhibitory concentration: 840 nM
Compound 4: the middle estimate sits 2.1-fold (0.33 log units) above what was measured; measured number outside the range, below it.
By their numbers in this assay, from the lowest: compounds 4, 1, 2 and 3 (each within the scatter of the next, the first and the last beyond it).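

In this assay, among the compounds shown here, the pair of compound 3 and compound 4 isolates this change for the first time, with the 4-chlorophenyl group held fixed, and gives a 3.5-fold lower number from compound 3 to compound 4 (0.54 log units; beyond the scatter), so dimethylamino in place of diethylamino at this place makes a difference that stands clear of the scatter. With dimethylamino held fixed, the group at the other end of the molecule can matter as well: chloro in place of tert-butyl on an aromatic carbon gives a 2.2-fold lower number from compound 2 to compound 4 (0.34 log units; beyond the scatter), whereas 4-chlorophenyl in place of 2-chlorophenyl gives a 1.3-fold lower number from compound 1 to compound 4 (0.11 log units; within the scatter), which does not separate the two chlorophenyl groups. No measurement at hand offers an explanation for any of these steps.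

Going by these compounds, the change at this position rests on a single pair, so whether it carries over to compounds with 2-chlorophenyl or 4-(tert-butyl)phenyl remains open. Also open, on these data alone, is how a cyclic amine such as pyrrolidine or morpholine, or a monomethylamino group, would stand on the same saturated chain carbon bound to an aromatic carbon.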